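Methoxy-to-Fluoro Exchange and Clearance in Liver Microsomes

The source may hold more compounds than are shown below. What is called first, only, known or untested is meant among the compounds shown, and "the series" means these compounds.

Compound 1 `COc1ccc(S(=O)(=O)c2cnc3c(F)cccc3c2-c2cccc(Cl)c2)cc1` gives 2.75 mL/min in an ADME assay on microsomes from liver (Homo sapiens) for metabolic stability, tested at 2.5 uM; on this read-out lower numbers stand for slow clearance and higher numbers for fast clearance.
Compound 2 `COc1ccc(-c2c(S(=O)(=O)c3cccc(F)c3)cnc3c(F)cccc23)cc1` gives 2.48 mL/min in this assay.
Compound 3 `O=S(=O)(c1ccc(F)cc1)c1cnc2c(F)cccc2c1-c1cccc(Cl)c1` gives 1.21 mL/min in this assay.

Compound 3 differs from compound 1 in a single change, (fluoro in place of methoxy on an aromatic carbon). In this assay that change produced a 2.3-fold lower number from compound 1 to compound 3 (0.36 log units; beyond the scatter). Compound 1 and compound 2 carry different cores, and the difference between the two cores is not broken down here; their values in this assay lie within the scatter of each other. Compound 4 `O=S(=O)(c1cccc(F)c1)c1cnc2c(F)cccc2c1-c1ccc(F)cc1` has not yet been measured. It stands to compound 2 as compound 3 stands to compound 1: fluoro in place of methoxy on an aromatic carbon. The place of the change is described in the same words in both pairs, so the same change occurs twice among these four compounds. Compound 4 is expected to show a step of a 2.3-fold lower number from compound 2 to compound 4 (0.35 log units; beyond the scatter) in this assay, because the same change already gave a 2.3-fold lower number from compound 1 to compound 3 (0.36 log units; beyond the scatter) and the change is made at the same place. The estimate for compound 4 is 1.1 mL/min, expected to fall between 0.6 mL/min and 2 mL/min.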

Compound 4, intrinsic clearance in a liver preparation (reported as CLH), per the amount of preparation that the assay uses: 0.19 mL/min
The estimate for compound 4 lay 5.8-fold (0.76 log units) above the measured number; measured number below the stated range.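

In this assay, fluoro in place of methoxy gave a 13-fold lower number from compound 2 to compound 4 (1.12 log units; beyond the scatter), so the number fell on this core as well. The direction of the change held on both cores, but its size did not carry from one to the other: the same change on two cores in this assay, a 2.3-fold lower number (0.36 log units; beyond the scatter) from compound 1 to compound 3 and a 13-fold lower number (1.12 log units; beyond the scatter) from compound 2 to compound 4, 5.7-fold (0.76 log units) apart, beyond the scatter of two such steps. In this series, then, these two pairs support carrying over the direction of the change but not a number for its size, and two pairs cannot show which feature of the cores goes with the larger step.

The compounds shown leave open how large the step would be on any further core, and whether the modest or the large step is the more usual one in this series. They also leave open how an amine or a carboxylic acid in place of the methoxy group would read in this assay, and whether such a replacement would depend on the core in the same way.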